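The compounds below may be only part of what the source reports. "The series", "measured", "known", "first", "only" and "open" are said of these compounds alone.

Going by the values given here, compound 1 `CCCc1nc(CC)c(C(=O)OCc2ccccc2OC)n1Cc1ccc(-c2ccccc2S(=O)(=O)NC(=O)OCCC(C)C)cc1F` gives the lowest of the two numbers so far in an assay on isolated protein for binding affinity to Type-2 angiotensin II receptor (Homo sapiens) (a lower number here means a stronger inhibitor, a higher number a weaker inhibitor), namely 1 nM. Its nearest neighbour, compound 2 `CCCc1nc(CC)c(C(=O)NCCCOc2ccccc2)n1Cc1ccc(-c2ccccc2S(=O)(=O)NC(=O)OCCC(C)C)cc1F`, gives 9 nM in this assay. The step between them is a 9.0-fold higher number from compound 1 to compound 2 (0.95 log units; beyond the scatter). Compound 3 `CCCc1nc(CC)c(C(=O)OCCN2C(=O)c3ccccc3C2=O)n1Cc1ccc(-c2ccccc2S(=O)(=O)NC(=O)OCCC(C)C)cc1F` differs from compound 1 elsewhere: a group of 12 heavy atoms (9 carbon, 1 nitrogen, 2 oxygen; one five-membered non-aromatic ring with 1 hetero atom, one six-membered aromatic ring of carbon only) in place of a group of 8 heavy atoms (7 carbon, 1 oxygen; one six-membered aromatic ring of carbon only), on a saturated chain carbon bound to an oxygen next to a carbonyl group. Among the compounds with values here, no measured step matches this change; the only comparison, from compound 1 to compound 2, altered a different part and cost a modest amount. A small loss of the same order is therefore expected for compound 3, about a 3.0-fold higher number from compound 1 to compound 3 (0.48 log units; beyond the scatter), giving an estimated 3 nM within 1 nM to 15 nM.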

Compound 3, half-maximal inhibitory concentration: 7 nM
For compound 3 the middle estimate is 2.3-fold (0.37 log units) below the measured one; low and high end bracket the measured number.
By their numbers in this assay, from the lowest: compound 1; then compounds 3 and 2 (each within the scatter of the next).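

In this assay, replacing the 2-methoxyphenyl group on a saturated chain carbon bound to an oxygen next to a carbonyl group gives a 7.0-fold higher number from compound 1 to compound 3 (0.85 log units; beyond the scatter), which shows that this position is sensitive to this change, though only modestly. Even with its group of 12 heavy atoms, compound 3 gives 7 nM. No available evidence accounts for this step. The compounds shown leave open whether an unsubstituted phenyl, an amine or a carboxylic acid at this position would match compound 1 or fall further from it.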